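This account rests on a few compounds, and the source may have more. Where it says the series, first, only, none or still open, it means among the compounds named here.

Of the compounds shown here, three sharing one core have been measured in a functional assay on the whole organism with Mus musculus as the target, in the maximal electroshock model, with a stated time of 0.5 h; a higher number here means that more compound is needed for the effect, a lower number that less compound is needed. Compound 1 `O=C(CCC(=O)c1ccccc1)Nc1nc2ccc(Cl)cc2s1` gives 300 mg/kg, and compound 2 `O=C(CCC(=O)c1ccccc1)Nc1nc2ccc([N+](=O)[O-])cc2s1` gives 300 mg/kg; the step between them, no change at the digits printed from compound 1 to compound 2 (within the scatter), is nitro in place of chloro on an aromatic carbon. Compound 3 `Cc1ccc2nc(NC(=O)CCC(=O)c3ccccc3)sc2c1` gives 100 mg/kg, the lowest of the three numbers: the steps of a 3.0-fold lower number from compound 1 to compound 3 (0.48 log units; beyond the scatter) and a 3.0-fold lower number from compound 2 to compound 3 (0.48 log units; beyond the scatter) each put methyl in place of the earlier group, and each lies beyond the scatter.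

The next compound, compound 4 `COc1ccc2nc(NC(=O)CCC(=O)c3ccccc3)sc2c1`, differs from compound 3 in one place: methoxy in place of methyl on an aromatic carbon. Within the data shown here, none of the three measured steps bears directly on this change; they concern the groups that methyl replaced, not what now replaces methyl, and no measured pair exchanges a methyl for a methoxy. The two steps ending at compound 3 show that swapping the group on this aromatic carbon can move the number, but they give no direction for methoxy. Compound 4 is therefore expected to sit near compound 3, with the step of no change at the digits printed from compound 3 to compound 4 (within the scatter) expected to fall within the scatter or only a little beyond it, and the range kept wide on the upper side. For compound 4 the estimate in this assay is 100 mg/kg, with a range from 50 mg/kg to 300 mg/kg.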

Compound 4, minimum effective dose: 30 mg/kg
Estimate against measurement, compound 4: 3.3-fold (0.52 log units) above; the measured number lies below the stated range.
By their numbers in this assay, from the lowest: compound 4; then compound 3; then compounds 1 and 2 (each within the scatter of the next).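

In this assay the step of a 3.3-fold lower number from compound 3 to compound 4 (0.52 log units; beyond the scatter) shows that methyl did not mark the low end at this aromatic carbon: methoxy in place of methyl moves the number further down, beyond the scatter. Among these compounds, measured against the other two groups, the steps are larger, with a 10-fold lower number from compound 2 to compound 4 (1.00 log units; beyond the scatter) for methoxy in place of nitro and a 10-fold lower number from compound 1 to compound 4 (1.00 log units; beyond the scatter) for methoxy in place of chloro, so this one position spans a wider range than the earlier compounds showed. The change itself is small, adding one oxygen and with it one hydrogen-bond acceptor to the group on this carbon, and among these four compounds the order runs from methoxy through methyl to chloro and nitro, the last two within the scatter of each other. Nothing given here accounts for why methoxy gives the lowest number.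

Still open, as far as these compounds go, is whether ethoxy, a hydroxyl group or an amine on the same aromatic carbon would continue this trend or reverse it. Also open, from the compounds shown here alone, is whether the gain from methoxy would hold with a longer chain or a substituted phenyl ring at the other end of the molecule.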